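This account rests on a few compounds, and the source may have more. Where it says the series, first, only, none or still open, it means among the compounds named here.

Measured so far:
- compound 1 `C/C(=N\NC(=O)COc1cccc2ccccc12)c1ccc(C#N)cc1Br` — 20 ug/mL
- compound 2 `O=C(COc1cccc2ccccc12)N/N=C/c1ccccc1Br` — >= 20 ug/mL
- compound 3 `C/C(=N\NC(=O)COc1cccc2ccccc12)c1ccccc1Br` — 20 ug/mL

All three compounds share the same core, an aryloxyacetyl hydrazone, and differ only in the ring hung on the carbon with a double bond to nitrogen. In an ADME assay on HEL cells (Homo sapiens) for cytotoxicity (on this read-out higher numbers stand for lower toxicity in this test and lower numbers for higher toxicity in this test), compound 1 gives 20 ug/mL. Compound 3 gives 20 ug/mL in this assay. For compound 2 the result is a limit of the assay rather than a number: >= 20 ug/mL, which puts it at the limit of >= 20 ug/mL in this assay, at which 1 of the 3 values shown sits.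

Going by the values given here, the one step that can be compared, no change at the digits printed from compound 1 to compound 3 (within the scatter), shows that swapping a group on that aromatic ring left the read-out unchanged within the scatter.

Compound 4 `CSc1ccc(/C=N/NC(=O)COc2cccc3ccccc23)cc1` has not yet been tested. It differs from compound 2 by 4-(methylsulfanyl)phenyl in place of 2-bromophenyl on a carbon with a double bond to nitrogen. This is again a change on the ring attached to the carbon with a double bond to nitrogen, the same place where the step from compound 1 to compound 3 produced no change. Among the compounds with values here, no bearing step is available for exchanging a 2-bromophenyl for a 4-(methylsulfanyl)phenyl, so the expectation rests on that single unchanged step and on the limit seen for compound 2.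

The expected step for compound 4 is therefore a number no higher from compound 2 to compound 4 (the limit leaves the size open), that is, none beyond the scatter. Compound 4 is estimated at 20 ug/mL, in a range from 10 ug/mL to 40 ug/mL, with a fair chance that this assay again reports only a limit.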

Compound 4, minimum cytotoxic concentration: >= 100 ug/mL
Compound 4: a limit, no number; the forecaster's own chance of this, stated with the estimate: 65%; middle value at least 5.0-fold (0.69 log units) away from the limit.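

In this assay, going by these compounds alone, compound 2 and compound 4 each give only a limit of the assay rather than a number, so no step between them can be read. The compounds shown leave open whether 4-(methylsulfanyl)phenyl in place of 2-bromophenyl changes the read-out at all, and by how much.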